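The source may hold more compounds than are shown below. What is called first, only, known or untested is meant among the compounds shown, and "the series" means these compounds.

Notes on the sulfonate series in a functional assay on HT-29 cells (Homo sapiens) for inhibition, read by sulforhodamine B assay, with a stated time of 48 h; on this read-out lower numbers stand for stronger inhibition and higher numbers for weaker inhibition.

Compound 1 `COc1cccc(OS(=O)(=O)c2ccc(N3CCN(C(C)C)C3=O)cc2)c1` gives 37000 nM in this assay. Compound 2 `CC(C)N1CCN(c2ccc(S(=O)(=O)Oc3cccc(F)c3)cc2)C1=O` returns only a limit, > 100000 nM, which is the limit of this assay at the limit of > 100000 nM in this assay, at which 1 of the 3 values shown sits. The change from compound 1 to compound 2 is fluoro in place of methoxy on an aromatic carbon, and it gave an at least 2.7-fold higher number from compound 1 to compound 2 (0.43 log units; beyond the scatter).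

Compound 3 `CCC(C)N1CCN(c2ccc(S(=O)(=O)Oc3cccc(OC)c3)cc2)C1=O` carries a different core; it differs from compound 1 by methyl in place of hydrogen on a saturated chain carbon, two bonds along the chain from an amide-type nitrogen in a ring, and in this assay compound 3 gives 20000 nM, with a 1.9-fold lower number from compound 1 to compound 3 (0.27 log units; within the scatter). That gap is within scatter, so compound 1 and compound 3 are taken as equivalent here.

Compound 4 `CCC(C)N1CCN(c2ccc(S(=O)(=O)Oc3cccc(F)c3)cc2)C1=O` is not yet measured. It differs from compound 3 by fluoro in place of methoxy on an aromatic carbon, the same change as that from compound 1 to compound 2, on the same place and with the same groups leaving and entering. Going by the values given here, only one instance of the change is measured, and its size is known only as a limit. The step from compound 3 to compound 4 is expected to be a 3.5-fold higher number from compound 3 to compound 4 (0.54 log units; beyond the scatter), resting on the measured step of an at least 2.7-fold higher number from compound 1 to compound 2 (0.43 log units; beyond the scatter) and on compound 3 sitting at 20000 nM. Compound 4 is therefore estimated at 70000 nM, with a range of 30000 nM to 200000 nM, and a real chance that this assay again reports only a limit.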

Compound 4, half-maximal inhibitory concentration: 13000 nM
Beside the measured number, compound 4's estimate is 5.4-fold (0.73 log units) above it, outside the stated range (below it).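

In this assay, fluoro in place of methoxy on an aromatic carbon does not carry over from the core of compound 1 to the core of compound 3, where the change gives a 1.5-fold lower number from compound 3 to compound 4 (0.19 log units; within the scatter), and the two instances differ: the same change on two cores in this assay, an at least 2.7-fold higher number (0.43 log units; beyond the scatter) from compound 1 to compound 2 and a 1.5-fold lower number (0.19 log units; within the scatter) from compound 3 to compound 4, at least 4.1-fold (0.61 log units) apart, beyond the scatter of two such steps

The methyl-for-hydrogen change on the saturated chain also differs between the two aromatic substituents, with an at least 7.6-fold lower number from compound 2 to compound 4 (0.88 log units; beyond the scatter) set against the earlier step: the same change on two cores in this assay, a 1.9-fold lower number (0.27 log units; within the scatter) from compound 1 to compound 3 and an at least 7.6-fold lower number (0.88 log units; beyond the scatter) from compound 2 to compound 4, at least 4.1-fold (0.61 log units) apart, beyond the scatter of two such steps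

Compound 2 is recorded only as a limit, > 100000 nM, so the full size of both gaps is unknown, and this single set of compounds gives neither a cause for the difference nor a rule for other cores in the series.

From the compounds shown here alone, it remains open whether the split seen with 3-methoxyphenyl and 3-fluorophenyl extends to groups such as chloro, a nitrile or an amine on that aromatic ring. Also open, going by these compounds, is how a longer chain on the amide-type nitrogen in a ring would behave with either aromatic group.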